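Swapping phenoxy for acetamidophenylsulfanyl in compound 2

The source may hold more compounds than are shown below. What is called first, only, known or untested is meant among the compounds shown, and "the series" means these compounds.

Compound 2 `COc1ccc(C2Nc3ccccc3C(=O)N2Cc2ccccc2)cc1COc1ccccc1` stands lowest of the two numbers in a functional assay on HEK-EM293 cells for agonist activity at Thyrotropin receptor (Homo sapiens), read by ELISA and cAMP accumulation, with a stated time of 1 h (a lower number here means a smaller maximal response, a higher number a larger maximal response), where it gives 25.6%, whereas compound 1 `COc1ccc(C2Nc3cccc(F)c3C(=O)N2Cc2ccccc2)cc1COc1ccc(NC(C)=O)cc1` gives 94.7%, a gap beyond the usual scatter. Compound 3 `COc1ccc(C2Nc3ccccc3C(=O)N2Cc2ccccc2)cc1CSc1ccc(NC(C)=O)cc1` is not yet measured; it differs from compound 2 by (4-acetamidophenyl)sulfanyl in place of phenoxy on a saturated chain carbon bound to an aromatic carbon. Among the measured compounds shown here, no step between measured compounds is known, so the size of the step from compound 2 to compound 3 is open; compound 1, which carries the same acetamidophenyl piece, gives 94.7%, and a rise is therefore expected. The expected step is a number 34.4 percentage points higher from compound 2 to compound 3 (beyond the scatter). Compound 3 is estimated at 60%, from 25% to 95%.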

Compound 3, largest response reached (Emax), in percent of the reference or control that the assay uses: 95.7%
The estimate for compound 3 lay 35.7 percentage points below the measured number; the measured number lies above the stated range.
By their numbers in this assay, from the lowest: compound 2; then compounds 1 and 3 (each within the scatter of the next).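

Within this assay, placing (4-acetamidophenyl)sulfanyl in place of phenoxy on a saturated chain carbon bound to an aromatic carbon gives a number 70.1 percentage points higher from compound 2 to compound 3 (beyond the scatter) and is the first single-place change that can be read here. It shows that the maximal response depends strongly on the group at this position. Nothing at hand explains the size of this large step.
As far as these compounds go, the change replaces the oxygen link with sulfur and adds the acetamido group together, so the share of each stays open. Whether an amine or a carboxylic acid in place of the acetamido group would keep the response is also unknown.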